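Hydroxamate-linked quinoline amides: aryl change on the pyridazinone nitrogen

This account rests on a few compounds, and the source may have more. Where it says the series, first, only, none or still open, it means among the compounds named here.

Measured compounds in a functional assay on A549 cells (Homo sapiens) for inhibition, read by MTT assay, with a stated time of 72 h; a lower number here means a stronger inhibitor, a higher number a weaker inhibitor:
compound 1 `COc1cc2c(Oc3ccc(NC(=O)c4nn(-c5ccccc5)ccc4=O)cc3)ccnc2cc1OCCCC(=O)NO` gives 9260 nM
compound 2 `COc1cc2c(Oc3ccc(NC(=O)c4nn(-c5cccc(C)c5)cc(C)c4=O)cc3)ccnc2cc1OCCCCCCC(=O)NO` gives 280 nM
compound 3 `COc1cc2c(Oc3ccc(NC(=O)c4nn(-c5ccc(C)cc5C)cc(C)c4=O)cc3)ccnc2cc1OCCCCCCC(=O)NO` gives 1840 nM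

Compound 3 stands second highest of the three numbers; compound 1 sits higher, compound 2 lower, both gaps beyond the scatter. Compound 4 `COc1cc2c(Oc3ccc(NC(=O)c4nn(-c5cccc(C(F)(F)F)c5)cc(C)c4=O)cc3)ccnc2cc1OCCCCCCC(=O)NO` differs from compound 3 by 3-(trifluoromethyl)phenyl in place of 2,4-dimethylphenyl on an aromatic nitrogen. Among the compounds with values here, the one step that bears on it is the aryl exchange a 6.6-fold higher number from compound 2 to compound 3 (0.82 log units; beyond the scatter), which raised the number beyond the scatter when 3-methylphenyl became 2,4-dimethylphenyl. Returning to a single substituent on the same ring is expected to reverse much of that, giving a lower number for compound 4 in this assay, expected step a 4.1-fold lower number from compound 3 to compound 4 (0.61 log units; beyond the scatter). Compound 4 is estimated at 450 nM, range 150 nM to 1500 nM.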

Compound 4, half-maximal inhibitory concentration: 780 nM
Compound 4: the middle estimate sits 1.7-fold (0.24 log units) below what was measured; the range from low to high includes it.
By their numbers in this assay, from the lowest: compound 2; then compound 4; then compound 3; then compound 1.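

In this assay the change to 3-(trifluoromethyl)phenyl gives a 2.4-fold lower number from compound 3 to compound 4 (0.37 log units; beyond the scatter) and so recovers part of the rise seen with 2,4-dimethylphenyl. Trifluoromethyl in place of methyl still gives a 2.8-fold higher number from compound 2 to compound 4 (0.44 log units; beyond the scatter) on the same ring, so the number at this position depends on the identity of the single substituent, not only on how many substituents the ring carries. Nothing at hand gives a reason for either step.

On these data alone, whether a methoxy group, a chlorine or an amine on this aryl ring would bring the number nearer to that of compound 2 stays open. So does whether the order of methyl and trifluoromethyl holds with a shorter hydroxamate chain.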